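This account rests on a few compounds, and the source may have more. Where it says the series, first, only, none or still open, it means among the compounds named here.

Measured in a physicochemical assay for metabolic stability, read by LC-MS, in simulated gastric fluid, with a stated time of 15 min, tested at 50 uM; on this read-out higher numbers stand for a more stable compound and lower numbers for a less stable compound:
- compound 1 (`COc1ccc(CNC(=O)c2c(C)nc3cc(C)ccn23)cc1`): 100%
- compound 2 (`CCC(=O)c1ccccc1OC(=O)c1coc(-c2ccccc2)n1`): 1.8%
- compound 3 (`O=C(Oc1c(Cl)cc(Cl)cc1Cl)c1coc(-c2ccccc2)n1`): 1.3%

Compound 2 sits at the low end of this small set. Its value of 1.8% lies within the scatter of compound 3 at 1.3%. Compound 1, at 100%, stands far beyond the scatter from both. Compound 2 and compound 3 are both esters and differ in their aryl part, yet their values cannot be told apart. Among the compounds with values here, compound 1 is an amide, but with only one such compound and a different core, this contrast is no established trend.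

Compound 4 (`O=C(Oc1ccccc1N1CCCC1)c1coc(-c2ccccc2)n1`) is also an ester, and it differs from compound 2 by pyrrolidin-1-yl in place of propanoyl on an aromatic carbon, ortho to a large group. Within the data shown here, no pair of measured compounds differs in one place, so the size of this change in this assay remains untested. The expectation rests on compound 2 at 1.8% and compound 3 at 1.3%. The expected change is a number 2.2 percentage points higher from compound 2 to compound 4 (within the scatter), slightly upward and most likely within the scatter. For compound 4 the estimate is 4%, with an expected range of 0.5% to 25%.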

Compound 4, percent of the compound remaining: 0.1%
Compound 4: the middle estimate sits 3.9 percentage points above what was measured; the measured number lies below the stated range.
By their numbers in this assay, from the lowest: compounds 4, 3 and 2 (each within the scatter of the next); then compound 1.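

In this assay, within the data shown here, the first comparison that differs in one place reads a number 1.7 percentage points lower from compound 2 to compound 4 (within the scatter), so on an aromatic carbon, ortho to a large group, pyrrolidin-1-yl in place of propanoyl gives no change that can be told from the scatter. This exchange of an open chain carrying a carbonyl for a five-membered non-aromatic ring carrying a nitrogen therefore does not lift compound 4 out of the low range, though with compound 2 already at 1.8% there is little room left for a lower number, and only an upward step could be read clearly at this position. Nothing available explains why the number stays this low in either compound.

As far as these compounds go, it remains open whether any other group at this place, such as a carboxylic acid or a dimethylamino group, would give a step beyond the scatter. From the compounds shown here alone, it also remains open what an amide in place of the ester would give on the core shared by compound 2 and compound 4.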